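From Compound 1 to Compound 3: One Group Exchanged

A few compounds are considered here, and "the series" means these few. Any claim that something is new, unique, unknown or untested is made for them only; others in the source may bear on it.

Compound 1 `COc1cccc(/C=C/C(=O)c2c(OC)cc(OC)cc2OC)c1`: 5300 nM
Compound 2 `COc1cc(OC)c(C(=O)/C=C/c2ccc([N+](=O)[O-])cc2)c(OC)c1`: 2800 nM

Only these two compounds have been measured in a functional assay on HaCaT cells (Homo sapiens) for cytotoxicity, with a stated time of 48 h; on this read-out lower numbers stand for stronger inhibition and higher numbers for weaker inhibition. Compound 1 stands within the usual scatter of compound 2, so the two values cannot be separated.

The next compound, compound 3 `COc1cc(OC)c(C(=O)/C=C/c2ccc(Br)cc2)c(OC)c1`, has not yet been measured. Relative to compound 1, it carries 4-bromophenyl in place of 3-methoxyphenyl on a double-bonded chain carbon bound to a double-bonded chain carbon.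

Going by the values given here, no measured pair isolates this exchange, so the data offer no direct guide to its size. Among the compounds with values here, the only available reference is compound 2, at 2800 nM, which lies within the scatter of compound 1. No step beyond the scatter is therefore expected in this assay. The estimated change is a 1.5-fold lower number from compound 1 to compound 3 (0.18 log units; within the scatter). For compound 3, the expected value is 3500 nM, with an estimated range of 1500 nM to 8000 nM.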

Compound 3, half-maximal inhibitory concentration: 9000 nM
The estimate for compound 3 lay 2.6-fold (0.41 log units) below the measured number; the measured number lies above the stated range.
By their numbers in this assay, from the lowest: compounds 2, 1 and 3 (each within the scatter of the next, the first and the last beyond it).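

In this assay, exchanging 3-methoxyphenyl for 4-bromophenyl on a double-bonded chain carbon bound to a double-bonded chain carbon gives a 1.7-fold higher number from compound 1 to compound 3 (0.23 log units; within the scatter), so this exchange cannot be told apart from no change. The exchange of bromo in place of nitro on an aromatic carbon gives a 3.2-fold higher number from compound 2 to compound 3 (0.51 log units; beyond the scatter), a modest step and the first one here to show that a single change on this ring can register beyond the scatter. Nothing at hand explains either step.

The compounds shown leave open where an amine or a carboxylic acid in place of bromo on that aromatic carbon would fall in this assay. They also leave open whether bromo and nitro would keep the same order on a core other than the shared core.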